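Swapping the Pyridin-4-yl Group for Pyrazin-2-yl

The source may report more compounds than this note shows. Statements on the series, on what has been measured and on what is new or still open speak of the compounds shown alone.

Three compounds sharing one core, which in compound 1 is `Nc1nc(NCc2cccs2)nc2sc(-c3ccco3)nc12`, differ only in the aromatic group attached through a saturated chain carbon bound to a nitrogen on an aromatic ring. In an assay on CHO cells for displacement of a labelled ligand from adenosine receptor A3 (Homo sapiens), read by scintillation counting, with a stated time of 120 min (a lower number here means a stronger inhibitor, a higher number a weaker inhibitor), compound 1 gives 6.43 nM. Compound 2, `Nc1nc(NCc2cccnc2)nc2sc(-c3ccco3)nc12`, gives 18.2 nM in this assay, and compound 3, `Nc1nc(NCc2ccncc2)nc2sc(-c3ccco3)nc12`, gives 827 nM. Compound 3 is the weakest of the three: the step of a 130-fold higher number from compound 1 to compound 3 (2.11 log units; beyond the scatter) and the step of a 45-fold higher number from compound 2 to compound 3 (1.66 log units; beyond the scatter) are both large, while a 2.8-fold higher number from compound 1 to compound 2 (0.45 log units; beyond the scatter) is modest. The pyridin-4-yl group thus sets compound 3 apart.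

Compound 4, `Nc1nc(NCc2cnccn2)nc2sc(-c3ccco3)nc12`, is not yet measured. It differs from compound 3 by pyrazin-2-yl in place of pyridin-4-yl on a saturated chain carbon bound to a nitrogen on an aromatic ring. The group that leaves is the one present only in the weakest compound, so the two large steps into compound 3 bear on this change and suggest the number should fall again. Compound 4 is therefore expected to show an 18-fold lower number from compound 3 to compound 4 (1.26 log units; beyond the scatter) in this assay, landing near 45 nM, with a likely range from 10 nM to 250 nM.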

Compound 4, inhibition constant: 157 nM
Estimate against measurement, compound 4: 3.5-fold (0.54 log units) below, within the range that was stated.
By their numbers in this assay, from the lowest: compound 1; then compound 2; then compound 4; then compound 3.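

Pyridin-4-yl is not the only group that can be exchanged at this place with a clear effect on the number: in this assay, pyrazin-2-yl gives a 5.3-fold lower number from compound 3 to compound 4 (0.72 log units; beyond the scatter), although both groups have 6 heavy atoms, so the change in the number comes with no change in that count. The recovery is only partial, since the same assay still shows an 8.6-fold higher number from compound 2 to compound 4 (0.94 log units; beyond the scatter) and a 24-fold higher number from compound 1 to compound 4 (1.39 log units; beyond the scatter), leaving thiophen-2-yl and pyridin-3-yl as the two better groups among those compared here. No other measurement is available to explain why these similarly sized rings differ so much.

The compounds shown leave open how a plain phenyl group, with no nitrogen in the ring, would compare. They also leave open what a longer chain between the ring and the amine nitrogen would do.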